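This account rests on a few compounds, and the source may have more. Where it says the series, first, only, none or still open, it means among the compounds named here.

Compound 1 `CCN(c1ccc(C#N)c(Cl)c1)c1cc(-c2ccncc2)ccc1C`: 3580 nM
Compound 2 `CCN(c1cccc(-n2ccnc2)c1)c1ccc(C#N)c(C(F)(F)F)c1`: > 30000 nM
Compound 3 `N#Cc1ccc(N2CCc3cc(-c4cnc5ccccc5c4)ccc3C2)cc1C(F)(F)F`: 25100 nM

Going by the values given here, in a functional assay on PC-3 cells (Homo sapiens) for antiproliferative activity, read by CCK-8 assay, with a stated time of 6 days (on this read-out lower numbers stand for stronger inhibition and higher numbers for weaker inhibition), compound 1 gives 3580 nM, the lower of the two numbers measured so far. Compound 3 gives 25100 nM, a gap beyond the usual scatter. For compound 2 the read-out is only a limit, > 30000 nM; (the limit of > 30000 nM in this assay, at which 1 of the 3 values shown sits). The unmeasured compound 4 `CCN(c1ccc(C#N)c(Cl)c1)c1cc(-c2cn[nH]c2)ccc1C` differs from compound 1 in one place: 1H-pyrazol-4-yl in place of pyridin-4-yl on an aromatic carbon. Among the compounds with values here, no measured pair shows this change, so its effect is uncertain; a smaller ring with a hydrogen-bond donor enters. A modest weakening, close to the edge of the scatter, is expected. Compound 4 is estimated at 6000 nM, most likely between 1500 nM and 25000 nM. The expected step is a 1.7-fold higher number from compound 1 to compound 4 (0.22 log units; within the scatter).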

Compound 4, half-maximal inhibitory concentration: 15300 nM
Compound 4: middle estimate off by 2.6-fold (0.41 log units), on the low side; the range from low to high includes it.
By their numbers in this assay, from the lowest: compound 1; then compounds 4 and 3 (each within the scatter of the next). At a limit, above all of these: compound 2.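

In this assay, placing 1H-pyrazol-4-yl in place of pyridin-4-yl on this aromatic carbon gives a 4.3-fold higher number from compound 1 to compound 4 (0.63 log units; beyond the scatter), so activity at this position depends on which ring it carries. Going by these compounds alone, this is the first pair here that differs in one place, and it shows that exchanging the six-membered ring for a five-membered ring with a hydrogen-bond donor weakens inhibition in this core.

One exchange cannot separate ring size from the added donor, and a plain phenyl or a 1-methylpyrazol-4-yl ring at this carbon would help to tell them apart. Nothing in the data shown explains the size of this step.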